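Acetoxy to hydroxy: following compound 3 to compound 4

This account rests on a few compounds, and the source may have more. Where it says the series, first, only, none or still open, it means among the compounds named here.

Compound 1 (`COc1ccc(OC)c(C2=C(c3cc(OC)c(OC)c(OC)c3)C(=O)CC2O[SiH2]C(C)(C)C)c1`): 5 ug/mL
Compound 2 (`COc1ccc(C2=C(c3cc(OC)c(OC)c(OC)c3)C(=O)C(O[SiH2]C(C)(C)C)C2)cc1OC(C)C`): 9 ug/mL
Compound 3 (`CC(=O)OC1C/C(=N/O)C(c2ccccc2)=C1c1ccccc1`): > 100 ug/mL (a limit of the assay, not a number)

In an ADME assay on HT-29 cells (Homo sapiens) for cytotoxicity, read by MTT assay, with a stated time of 72 h (on this read-out lower numbers stand for stronger inhibition and higher numbers for weaker inhibition), compound 3 reads > 100 ug/mL and this is a limit, not a number. Compound 1 (5 ug/mL) and compound 2 (9 ug/mL) both gave true numbers, and these two lie within the usual scatter of each other.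

Compound 4 (`O/N=C1/CC(O)C(c2ccccc2)=C1c1ccccc1`) differs from compound 3 in one place (hydrogen in place of acetyl on an oxygen on a saturated carbon). Hydrogen stands in place of acetyl on an oxygen on a saturated carbon, so acetoxy becomes hydroxy. Going by the values given here, no measured pair of compounds shows this change, so its effect in this assay has no direct precedent here. Among the compounds with values here, the only guide is compound 3 itself (> 100 ug/mL), the closest relative, and its reading is a limit. The step expected is a number no higher from compound 3 to compound 4 (the limit leaves the size open) and it is estimated to stay small, with no firm direction beyond the scatter. The estimated value for compound 4 is 100 ug/mL (expected range 35 ug/mL to 300 ug/mL).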

Compound 4, half-maximal inhibitory concentration: > 100 ug/mL
Compound 4: a limit, no number; the forecaster's own chance of this, stated with the estimate: 60%; the middle value lies on the limit itself.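

No step can be read between compound 3 and compound 4, because both readings are limits and not numbers: the limit of > 100 ug/mL in this assay, at which 2 of the 4 values shown sit. The compounds shown leave open whether going from acetoxy to hydroxy changes the reading at all.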